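Ring size at the chain end: pyrrolidine to piperidine

The compounds below may be only part of what the source reports. "The series", "measured", "known", "first", "only" and "open" are said of these compounds alone.

Compound 1, `COc1cc2c(Oc3ccc(NC(=O)c4nn(-c5ccccc5C)c(=O)cc4C)cc3F)ccnc2cc1OCCCN1CCCCC1`: 1310 nM
Compound 2, `COc1ccc(-n2nc(C(=O)Nc3ccc(Oc4ccnc5cc(OCCCN6CCCC6)c(OC)cc45)c(F)c3)c(C)cc2=O)cc1`: 1290 nM

In a functional assay on MKN-45 cells (Homo sapiens) for inhibition, read by MTT assay, with a stated time of 72 h (a lower number here means a stronger inhibitor, a higher number a weaker inhibitor), compound 2 gives 1290 nM, and compound 1 gives 1310 nM; the two numbers fall within the usual scatter of each other, so compound 2 stands level with compound 1. Compound 3, `COc1ccc(-n2nc(C(=O)Nc3ccc(Oc4ccnc5cc(OCCCN6CCCCC6)c(OC)cc45)c(F)c3)c(C)cc2=O)cc1`, carries the change (piperidin-1-yl in place of pyrrolidin-1-yl on a saturated chain carbon, three bonds along the chain from an oxygen on an aromatic ring). For the measured compounds named here, no measured pair shows this change alone, so the step from compound 2 to compound 3 is expected to stay within the scatter, in no definite direction, as a 1.0-fold higher number from compound 2 to compound 3 (0.00 log units; within the scatter). Compound 3 is therefore estimated at 1300 nM, with a range from 650 nM to 2600 nM.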

Compound 3, half-maximal inhibitory concentration: 330 nM
Beside the measured number, compound 3's estimate is 3.9-fold (0.60 log units) above it; measured number outside the range, below it.
By their numbers in this assay, from the lowest: compound 3; then compounds 2 and 1 (each within the scatter of the next).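

In this assay, 3-(piperidin-1-yl)propyl in place of 3-(pyrrolidin-1-yl)propyl gives a 3.9-fold lower number from compound 2 to compound 3 (0.59 log units; beyond the scatter), so the ring at the chain end moves the number, which compounds 1 and 2 alone could not show. With piperidin-1-yl held, the group on the aromatic nitrogen matters too: 4-methoxyphenyl in place of 2-methylphenyl gives a 4.0-fold lower number from compound 1 to compound 3 (0.60 log units; beyond the scatter). Nothing shown explains either step.

On these data alone, whether a morpholin-4-yl or 4-methylpiperazin-1-yl ring at the chain end would match piperidin-1-yl remains open. So does the effect of a shorter or longer chain carrying that ring.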